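The source may report more compounds than this note shows. Statements on the series, on what has been measured and on what is new or still open speak of the compounds shown alone.

In a functional assay for agonist activity at G protein-coupled receptor 88 (Homo sapiens), read by HTRF and cAMP accumulation (a higher number here means that more compound is needed for the effect, a lower number that less compound is needed), three compounds have been measured so far. Compound 1 `CC[C@@H](C)[C@H](N)CN(C(=O)[C@@H]1C[C@H]1c1ccccc1)c1ccc(-c2ccccc2)cc1` gives 1.4 nM. For the measured compounds named here, compound 2 `CC(C)(C)[C@H](N)CN(C(=O)[C@@H]1C[C@H]1c1ccccc1)c1ccc(-c2ccccc2)cc1` gives 11 nM, and the single measured step, a 7.9-fold higher number from compound 1 to compound 2 (0.90 log units; beyond the scatter), alters the chain that carries the amine nitrogen. Compound 3 `CC[C@H](C)[C@H](N)CN(C(=O)[C@@H]1C[C@H]1c1ccc(F)cc1)c1ccc(-c2ccccc2)cc1` gives 600 nM, the highest of the three numbers; compound 2 comes nearest to it and compound 1 lies furthest from it. Compound 3 and compound 1 differ in two places, so their two values stand side by side without a step between them.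

Compound 4 `CC[C@H](C)[C@H](N)CN(C(=O)[C@@H]1C[C@H]1c1ccoc1)c1ccc(-c2ccccc2)cc1` differs from compound 3 in one place: furan-3-yl in place of 4-fluorophenyl on a saturated ring carbon. Going by the values given here, no measured step bears on this part of the molecule. The step from compound 1 to compound 2 concerns the saturated chain and not the group on a saturated ring carbon of the three-membered non-aromatic ring, so it offers no guide to the direction of the present change. With nothing measured at this position, only a modest step is expected in this assay, in no clear direction beyond the scatter. Compound 4 is therefore estimated at 900 nM, with a range from 250 nM to 3500 nM. This amounts to an expected step of a 1.5-fold higher number from compound 3 to compound 4 (0.18 log units; within the scatter).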

Compound 4, half-maximal effective concentration: 580 nM
Estimate against measurement, compound 4: 1.6-fold (0.19 log units) above; the measured number falls inside the stated range.
By their numbers in this assay, from the lowest: compound 1; then compound 2; then compounds 4 and 3 (each within the scatter of the next).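

In this assay, for the compounds shown here, the exchange of 4-fluorophenyl for furan-3-yl gives a 1.0-fold lower number from compound 3 to compound 4 (0.01 log units; within the scatter), the first measured step on a saturated ring carbon of the three-membered non-aromatic ring. Between this pair, therefore, a six-membered aromatic ring of carbon only and a five-membered aromatic ring with one hetero atom cannot be told apart in this assay, although furan-3-yl has fewer heavy atoms, replaces the fluorine with a ring oxygen and adds a hydrogen-bond acceptor. Nothing available here accounts for this result.

As far as these compounds go, this single step was read on one chain, so it remains open whether the same exchange would also fall within the scatter on the differently arranged sec-butyl chain of compound 1 or the tert-butyl chain of compound 2. It also leaves open how other groups at this place, such as thiophen-3-yl, pyridin-3-yl or 4-methoxyphenyl, would compare with 4-fluorophenyl and furan-3-yl on the same chain.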